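This account rests on a few compounds, and the source may have more. Where it says the series, first, only, none or still open, it means among the compounds named here.

Compound 1 `CCSc1ccccc1C1=NC(c2ccccc2)CO1` gives 4.04
Compound 2 `CSc1ccccc1C1=NC(c2ccccc2)CO1` gives 3.5
Compound 3 `FC(F)(F)c1ccccc1C1=NC(c2ccccc2)CO1` gives 3.71

In a physicochemical assay for lipophilicity (a higher number here means a more lipophilic compound, a lower number a more polar compound), compound 3 at 3.71 stands within the scatter of compound 2, while compound 1 lies clearly apart: a number 0.33 log units lower from compound 1 to compound 3 (beyond the scatter).

The unmeasured compound 4 `O=[N+]([O-])c1ccccc1C1=NC(c2ccccc2)CO1` has nitro in place of trifluoromethyl on an aromatic carbon, ortho to a large group: nitro in place of trifluoromethyl on an aromatic carbon.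

Within the data shown here, no measured step makes this exact exchange, so the evidence is indirect. Two steps replace one group with another on an aromatic carbon: a number 0.21 log units higher from compound 2 to compound 3 (within the scatter) and a number 0.33 log units lower from compound 1 to compound 3 (beyond the scatter). A third, a number 0.54 log units lower from compound 1 to compound 2 (beyond the scatter), shows the size of a small edit to the chain on sulfur. All three are modest or lie within the scatter, but none brings in nitro, so they offer only a rough scale.

The structural comparison adds one clue: of the two groups exchanged here, only the entering one carries hydrogen-bond acceptors. A fall in this assay beyond the scatter, and larger than any measured step, is therefore expected, though this rests on limited evidence. The expected step is a number 0.81 log units lower from compound 3 to compound 4 (beyond the scatter). For compound 4 the estimated value is 2.9, with an expected range from 2.5 to 3.4.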

Compound 4, partition coefficient: 2.83
Beside the measured number, compound 4's estimate is 0.07 log units above it; low and high end bracket the measured number.
By their numbers in this assay, from the lowest: compound 4; then compounds 2 and 3 (each within the scatter of the next); then compound 1.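

In this assay, nitro on an aromatic carbon, ortho to a large group, takes the number lower than any of the three earlier groups at that place, with a number 0.88 log units lower from compound 3 to compound 4 (beyond the scatter) and a number 0.67 log units lower from compound 2 to compound 4 (beyond the scatter) and then a number 1.21 log units lower from compound 1 to compound 4 (beyond the scatter) as the largest step of the set. The earlier compounds shown here, which carry ethylsulfanyl, methylsulfanyl or trifluoromethyl here, span a much narrower range, so this one position can move the number further than they suggested. The exchange of trifluoromethyl for nitro swaps a group with 0 hydrogen-bond acceptors for one with 2 hydrogen-bond acceptors, but that is only a count, and nothing shown here establishes why the number falls.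

The compounds shown leave open whether other groups on this aromatic carbon, such as an amine, a nitrile or a carboxylic acid, would reach numbers as low as nitro does or fall somewhere within the range of the earlier groups. They also leave open whether nitro would give a step of similar size on another carbon of the same six-membered aromatic ring, away from the large group.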